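Swapping Methoxy for Chloro on a Shared Core

This account rests on a few compounds, and the source may have more. Where it says the series, first, only, none or still open, it means among the compounds named here.

For the measured compounds named here, compound 1 `COc1ccc(C/N=c2\c(O)c(O)\c2=N/C(C)(C)C)cc1` is one of three compounds measured in a functional assay for inhibition, with Rattus norvegicus as the target; a higher number here means a weaker inhibitor, a lower number a stronger inhibitor. In this assay compound 1 gives 4800 nM, the second highest of the three numbers. Compound 2 `Cc1cc(Cl)cc(Cl)c1C/N=c1\c(O)c(O)\c1=N/C(C)C(C)(C)C` gives 9800 nM, the highest number, which makes it the weakest inhibitor of the three. Compound 3 `CCC(C)(C)/N=c1\c(O)c(O)\c1=N/Cc1ccc(F)c(F)c1` gives 1600 nM, the lowest number, which makes it the strongest inhibitor of the three. Both gaps from compound 1 lie beyond the usual scatter.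

Compound 4 `CC(C)(C)/N=c1\c(O)c(O)\c1=N/Cc1ccc(Cl)cc1` has not yet been measured. It differs from compound 1 in a single place: chloro in place of methoxy on an aromatic carbon. Going by the values given here, no measured pair shows this exact change, so its size cannot be read off directly. The other two compounds both carry halogens on their aromatic rings, yet one is the strongest and one the weakest, so they point in no single direction. A modest step toward a lower number, close to the edge of the scatter, is expected: a 1.6-fold lower number from compound 1 to compound 4 (0.20 log units; within the scatter). Compound 4 is therefore estimated at 3000 nM, with a likely range from 1000 nM to 9000 nM.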

Compound 4, half-maximal inhibitory concentration: 1700 nM
Compound 4: the middle estimate sits 1.8-fold (0.25 log units) above what was measured; low and high end bracket the measured number.
By their numbers in this assay, from the lowest: compounds 3 and 4 (each within the scatter of the next); then compound 1; then compound 2.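

Chloro in place of methoxy, on an aromatic carbon para to a large group, gives a 2.8-fold lower number from compound 1 to compound 4 (0.45 log units; beyond the scatter) in this assay and is the first change here that can be read on its own, with the rest of the molecule held the same. For the compounds shown here, it shows that the group at this position can move the number beyond the usual scatter, and that chloro here goes with the stronger inhibitor, which the earlier compounds, differing in several places at once, could not show. No measurement at hand explains why the number moves.

Going by these compounds, whether an amine, a nitrile or a carboxylic acid at this position would give a number nearer that of chloro or of methoxy remains open. So does whether the same swap gives a similar step on a different substitution pattern around the shared core.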